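The source may report more compounds than this note shows. Statements on the series, on what has been measured and on what is new or still open speak of the compounds shown alone.

Measured compounds in a physicochemical assay for lipophilicity, using the shake flask method; a higher number here means a more lipophilic compound, a lower number a more polar compound:
compound 1 `C=CCO/N=C/c1c(N)ncnc1Oc1ccc(NC(=O)C2(C(=O)Nc3ccc(F)cc3)CC2)cc1F`: 3.65
compound 2 `C#CCO/N=C/c1c(N)ncnc1Oc1ccc(NC(=O)C2(C(=O)Nc3ccc(F)cc3)CC2)cc1F`: 3.34
compound 3 `Nc1ncnc(Oc2ccc(NC(=O)C3(C(=O)Nc4ccc(F)cc4)CC3)cc2F)c1/C=N/OCc1ccccc1`: 4.45

Compound 1 stands second highest of the three, with compound 2 nearest and compound 3 furthest. Compound 4 `Nc1ncnc(Oc2ccc(NC(=O)C3(C(=O)Nc4ccc(F)cc4)CC3)cc2F)c1/C=N/OCCCN1CCCC1` differs from compound 1 as follows: 2-(pyrrolidin-1-yl)ethyl in place of vinyl on a saturated chain carbon bound to an oxygen on an unsaturated carbon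

Both measured steps at this place replace vinyl: a number 0.31 log units lower from compound 1 to compound 2 (beyond the scatter) and a number 0.80 log units higher from compound 1 to compound 3 (beyond the scatter). Among the measured compounds shown here, neither entering group carries a hydrogen-bond acceptor, so no measured step matches the present change directly; the entering group here adds one hydrogen-bond acceptor and a ring. A drop beyond the scatter is expected in this assay, larger than the step to compound 2. For compound 4 the estimate is 2.6, range 1.9 to 3.3, a step of a number 1.05 log units lower from compound 1 to compound 4 (beyond the scatter).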

Compound 4, partition coefficient: 3.82
For compound 4 the middle estimate is 1.22 log units below the measured one, and the stated range ends below it.
By their numbers in this assay, from the lowest: compound 2; then compounds 1 and 4 (each within the scatter of the next); then compound 3.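

Putting 2-(pyrrolidin-1-yl)ethyl in place of vinyl gives a number 0.17 log units higher from compound 1 to compound 4 (within the scatter) in this assay despite the added ring and hydrogen-bond acceptor. The same group gives a number 0.63 log units lower from compound 3 to compound 4 (beyond the scatter) and a number 0.48 log units higher from compound 2 to compound 4 (beyond the scatter) at this place, so a group carrying a hydrogen-bond acceptor here falls inside the span set by ethynyl and phenyl. Nothing on hand accounts for this result. The compounds shown leave open how a dimethylamino group or a carboxylic acid at the end of the same chain would read in this assay and whether a shorter chain carrying the pyrrolidine ring would read the same.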